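A few compounds are considered here, and "the series" means these few. Any claim that something is new, unique, unknown or untested is made for them only; others in the source may bear on it.

Series in a functional assay on B16-F10 cells (Mus musculus) for antiproliferative activity, read by MTT assay, with a stated time of 48 h; on this read-out higher numbers stand for weaker inhibition and lower numbers for stronger inhibition:
- compound 1 `CCCCCCCCCCCCOc1ccc(C(=O)/C=C/c2c(/C=C/c3ccc(OC)cc3)cc(OC)cc2OC)cc1`: 12.7 ug/mL
- compound 2 `COc1ccc(/C=C/c2cc(OC)cc(OC)c2/C=C/C(=O)c2cccc(Br)c2)cc1`: 5.1 ug/mL
- compound 3 `CCCCCCOc1ccc(C(=O)/C=C/c2c(/C=C/c3ccc(OC)cc3)cc(OC)cc2OC)cc1`: 10.4 ug/mL

Compound 2 has the lowest number of the three, and its gaps to compound 3 and to compound 1 both lie beyond the scatter. Compound 4 `COc1ccc(/C=C/c2cc(OC)cc(OC)c2/C=C/C(=O)c2ccc(F)cc2)cc1` departs from compound 2 by one change: 4-fluorophenyl in place of 3-bromophenyl on a carbonyl carbon. In words, this is 4-fluorophenyl in place of 3-bromophenyl on a carbonyl carbon.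

Among the compounds with values here, the only measured step, a 1.2-fold lower number from compound 1 to compound 3 (0.09 log units; within the scatter), lies within the scatter, and it alters a chain rather than exchanging one halogen-bearing phenyl group for another. Within the data shown here, no measured pair isolates the change at hand, so its size remains open. The values do show that compound 2, with the 3-bromophenyl group, sits lower in this assay than the two compounds with chain-bearing groups on the same carbonyl carbon. This suggests that the group at this place can matter, but it gives no direction for the exchange of halogen and ring position.

The expectation therefore stays close to compound 2 at 5.1 ug/mL, with a slight allowance towards the higher values of the series. The estimated change is a 1.2-fold higher number from compound 2 to compound 4 (0.07 log units; within the scatter), and no step beyond the scatter is expected. For compound 4 the expected value is 6 ug/mL, with an estimated range from 2.8 ug/mL to 13 ug/mL.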

Compound 4, half-maximal inhibitory concentration: 5.3 ug/mL
For compound 4 the middle estimate is 1.1-fold (0.05 log units) above the measured one; measured number inside the range.
By their numbers in this assay, from the lowest: compounds 2, 4, 3 and 1 (each within the scatter of the next, the first and the last beyond it).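

In this assay the exchange at the carbonyl carbon gives a 1.0-fold higher number from compound 2 to compound 4 (0.02 log units; within the scatter), so replacing 3-bromophenyl with 4-fluorophenyl, which alters both the halogen and its place on the phenyl ring in a single step, does not take the number outside the scatter. Within the data shown here, the result also gives the first direct reading between a halogen and a chain-bearing group on this phenyl ring: fluoro in place of hexyloxy on an aromatic carbon gives a 2.0-fold lower number from compound 3 to compound 4 (0.29 log units; within the scatter), and this step also stays within the scatter, although it removes the whole hexyl chain together with its oxygen. Nothing on hand explains why these exchanges leave the numbers so close.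

As far as these compounds go, because halogen and placement change together from compound 2 to compound 4, their separate contributions remain unknown, and 3-fluorophenyl and 4-bromophenyl would be the pair that could pull them apart. From the compounds shown here alone, it also remains open whether a phenyl group carrying an amine or a carboxylic acid, or a pyridine ring in place of the phenyl ring, on the same carbonyl carbon would give a step beyond the scatter.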